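Swapping Isopropylphenyl for Difluorophenyl on the Shared Core

A few compounds are considered here, and "the series" means these few. Any claim that something is new, unique, unknown or untested is made for them only; others in the source may bear on it.

Compound 3 `CC(C)c1ccc(Nc2ccc3c(OCCCN4CCN(C)CC4)cccc3n2)cc1` stands weakest of the three measured compounds: in a functional assay on PC-3 cells (Homo sapiens) for inhibition, read by sulforhodamine B assay, with a stated time of 48 h (on this read-out higher numbers stand for weaker inhibition of growth and lower numbers for stronger inhibition of growth), compound 3 gives 12900 nM, whereas compound 1 `CN1CCN(CCCOc2cccc3nc(Nc4ccc(Cl)c(C(F)(F)F)c4)ccc23)CC1` gives 1570 nM and compound 2 `CN1CCN(CCCOc2cccc3nc(Nc4ccc(Cl)c(F)c4)ccc23)CC1` gives 1760 nM. Compound 4 `CN1CCN(CCCOc2cccc3nc(Nc4ccc(F)c(F)c4)ccc23)CC1` differs from compound 3 in one place: 3,4-difluorophenyl in place of 4-isopropylphenyl on a nitrogen on an aromatic ring. Within the data shown here, two measured steps bear on this change, both running the other way, from a halogen-bearing phenyl ring to the 4-isopropylphenyl: an 8.2-fold higher number from compound 1 to compound 3 (0.91 log units; beyond the scatter) and a 7.3-fold higher number from compound 2 to compound 3 (0.87 log units; beyond the scatter). Since compound 4 again carries a halogen-bearing phenyl ring, the reverse of those steps is expected, namely a move toward stronger inhibition of growth, a 7.2-fold lower number from compound 3 to compound 4 (0.86 log units; beyond the scatter). Compound 4 is therefore estimated in this assay at 1800 nM, within a range of 800 nM to 4500 nM.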

Compound 4, concentration for 50% growth inhibition: 3830 nM
Compound 4: middle estimate off by 2.1-fold (0.33 log units), on the low side; measured number inside the range.
By their numbers in this assay, from the lowest: compounds 1 and 2 (each within the scatter of the next); then compound 4; then compound 3.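

In this assay the 3,4-difluorophenyl regains only part of the ground lost with the 4-isopropylphenyl (a 3.4-fold lower number from compound 3 to compound 4 (0.53 log units; beyond the scatter)), and it does not match the other halogen-bearing rings (a 2.2-fold higher number from compound 2 to compound 4 (0.34 log units; beyond the scatter); a 2.4-fold higher number from compound 1 to compound 4 (0.39 log units; beyond the scatter)). So halogens on this ring are not interchangeable: fluoro in place of chloro between compound 2 and compound 4 moves the number beyond the scatter, whereas fluoro in place of trifluoromethyl between compound 1 and compound 2 stays within it. Nothing available here explains this order. Still open, as far as these compounds go, is how a ring carrying a nitrile, a methoxy group or an amine would rank on this nitrogen.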